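Hydroxyalkyl Side Chains on a Shared Purine-Type Core

This account rests on a few compounds, and the source may have more. Where it says the series, first, only, none or still open, it means among the compounds named here.

Compound 1 `CC[C@H](Nc1nc(NCc2ccccn2)c2ncn(C(C)C)c2n1)C(O)C(C)(C)C`: 28000 nM
Compound 2 `CC[C@H](Nc1nc(NCc2ccccn2)c2ncn(C(C)C)c2n1)C(C)O`: 20000 nM
Compound 3 `CCC(O)[C@H](CC)Nc1nc(NCc2ccccn2)c2ncn(C(C)C)c2n1`: > 50000 nM

Three compounds sharing one core were measured in a functional assay on HT-29 cells (Homo sapiens) for inhibition, read by sulforhodamine B assay, with a stated time of 96 h; on this read-out higher numbers stand for weaker inhibition of growth and lower numbers for stronger inhibition of growth. Compound 1 `CC[C@H](Nc1nc(NCc2ccccn2)c2ncn(C(C)C)c2n1)C(O)C(C)(C)C` gives 28000 nM in this assay, and compound 2 `CC[C@H](Nc1nc(NCc2ccccn2)c2ncn(C(C)C)c2n1)C(C)O` gives 20000 nM; the step of a 1.4-fold lower number from compound 1 to compound 2 (0.15 log units; within the scatter) lies within the scatter. Compound 3 `CCC(O)[C@H](CC)Nc1nc(NCc2ccccn2)c2ncn(C(C)C)c2n1` reaches only the limit (the limit of > 50000 nM in this assay, at which 1 of the 3 values shown sits), so compound 3 stands at the weak end of what was shown, with no number of its own.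

Compound 4 `CC[C@@H](Nc1nc(NCc2ccccn2)c2ncn(C(C)C)c2n1)C(C)O` is not yet measured. It differs from compound 3 by 1-(1-hydroxyethyl)propyl in place of 1-ethyl-2-hydroxybutyl on a nitrogen on an aromatic ring. The measured step closest to this change is an at least 2.5-fold higher number from compound 2 to compound 3 (0.39 log units; beyond the scatter), which runs in the opposite direction to the one now taken, and an at least 1.7-fold higher number from compound 1 to compound 3 (0.25 log units; that floor lies within the scatter) points the same way. Reversing that step, compound 4 is expected to give a lower number than compound 3, though how much of this the new stereocentre preserves cannot be told from compound 1, compound 2 and compound 3 alone.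

Compound 4 is therefore expected to give about 35000 nM in this assay, between 15000 nM and 80000 nM, a step of an at least 1.4-fold lower number from compound 3 to compound 4 (0.15 log units; that floor lies within the scatter).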

Compound 4, concentration for 50% growth inhibition: 42000 nM
Compound 4: the middle estimate sits 1.2-fold (0.08 log units) below what was measured; low and high end bracket the measured number.
By their numbers in this assay, from the lowest: compounds 2, 1 and 4 (each within the scatter of the next, the first and the last beyond it). At a limit, above all of these: compound 3.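

The new result shows that the configuration of this side chain can matter in this assay: with the same atoms and bonds, a stereocentre at a saturated chain carbon drawn S in compound 2 and R in compound 4 goes with a 2.1-fold higher number from compound 2 to compound 4 (0.32 log units; beyond the scatter). This reading carries one caution, so the step cannot be assigned cleanly to that single centre: the fact that one of compounds 2 and 4 is drawn with a defined configuration and the other without, at the place where they differ The change of side chain on the nitrogen gives no comparable separation, since the step to 1-(1-hydroxyethyl)propyl from 1-ethyl-2-hydroxybutyl is an at least 1.1-fold lower number from compound 3 to compound 4 (0.07 log units; that floor lies within the scatter), and the step from 1-ethyl-2-hydroxy-3,3-dimethylbutyl is a 1.5-fold higher number from compound 1 to compound 4 (0.18 log units; within the scatter).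

Going by these compounds, compound 3 remains a limit and not a number, so its true distance from compound 4 stays open: the limit of > 50000 nM in this assay, at which 1 of the 4 values shown sits. Also open is whether a side chain carrying an amine or a carboxylic acid in place of the hydroxyl would keep or lose the growth inhibition seen here, and what each defined configuration of the hydroxyl-bearing carbon would give on its own.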